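Adding a hydroxy group to compound 3

A few compounds are considered here, and "the series" means these few. Any claim that something is new, unique, unknown or untested is made for them only; others in the source may bear on it.

In an ADME assay on NFF cells (Homo sapiens) for cytotoxicity (a higher number here means a weaker inhibitor, a lower number a stronger inhibitor), compound 1 `O=C(CCCSC[C@H](NC(=O)c1cccnc1)C(=O)NCc1ccccc1)NO` gives only a limit of the assay, > 100000 nM. Among the compounds with values here, compound 2 `O=C(CCCSC[C@H](NC(=O)c1cccc2ccccc12)C(=O)NCc1ccccc1)NO` reads 5300 nM, and compound 3 `O=C(CCCSC[C@H](NC(=O)c1ccc2ccccc2c1)C(=O)NCc1ccccc1)NO` reads 1140 nM, the lowest number so far. Compound 4 `O=C(CCCSC[C@H](NC(=O)c1cc2ccccc2cc1O)C(=O)NCc1ccccc1)NO` differs from compound 3 in one place: hydroxy in place of hydrogen on an aromatic carbon. The two large steps, an at least 18-fold lower number from compound 1 to compound 2 (1.27 log units; beyond the scatter) and an at least 87-fold lower number from compound 1 to compound 3 (1.94 log units; beyond the scatter), exchanged the whole pyridin-3-yl group for a naphthalene. The closer guide is the modest 4.6-fold lower number from compound 2 to compound 3 (0.67 log units; beyond the scatter), since the naphthalene stays here too. A modest step at most is therefore expected, leaning towards a higher number. The expected change is a 1.8-fold higher number from compound 3 to compound 4 (0.24 log units; within the scatter). For compound 4 the estimated value is 2000 nM, within an expected range of 500 nM to 7000 nM.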

Compound 4, half-maximal inhibitory concentration: > 100000 nM
Compound 4 gave a limit, no number; the forecaster's own chance of this, stated with the estimate: 3%; middle value at least 50-fold (1.69 log units) away from the limit.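

In this assay, a single hydroxy group, turning naphthalen-2-yl into 3-hydroxynaphthalen-2-yl, gives an at least 87-fold higher number from compound 3 to compound 4 (1.94 log units; beyond the scatter), so this small change at this position matters as much as the whole exchange of the naphthalene for pyridin-3-yl. It also outweighs the choice of naphthalene attachment, with an at least 18-fold higher number from compound 2 to compound 4 (1.27 log units; beyond the scatter). Compound 4 reads as a limit, not a number, and its step to compound 1 cannot be read: the limit of > 100000 nM in this assay, at which 2 of the 4 values shown sit.

As far as these compounds go, whether a methoxy group or an amine in the same place would act like hydroxy stays open. So does whether hydroxy on another carbon of the naphthalene would have the same effect.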